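Cytotoxicity notes on the tosyl asparagine amide series

The compounds below may be only part of what the source reports. "The series", "measured", "known", "first", "only" and "open" are said of these compounds alone.

Compound 1 `Cc1ccc(S(=O)(=O)N[C@@H](CC(=O)NC(C)(C)C)C(=O)NCCNC(=O)c2c(O)cccc2F)cc1`: in an ADME assay on HepG2 cells (Homo sapiens) for cytotoxicity (on this read-out lower numbers stand for an effect already at smaller amounts and higher numbers for an effect only at larger amounts of compound), compound 1 reaches only the limit > 11000 nM.
Compound 2 `Cc1ccc(S(=O)(=O)N[C@@H](CC(=O)NC(C)(C)C)C(=O)NCCNC(=O)c2cccc(O)c2)cc1`: in this assay compound 2 reaches only the limit > 11000 nM.
Compound 3 `Cc1ccc(S(=O)(=O)N[C@@H](CC(=O)NC(C)(C)C)C(=O)NCCNC(=O)c2ccccc2O)cc1`: in this assay compound 3 reaches only the limit > 11000 nM.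

All three measured values are limits of the assay, not numbers, so compound 3 stands at the same limit as the other two, with no readable difference among them, as summarised by the limit of > 11000 nM in this assay, at which 3 of the 3 values shown sit. The three measured steps are accordingly unreadable: a step that the two limits leave unreadable from compound 1 to compound 2, a step that the two limits leave unreadable from compound 1 to compound 3 and a step that the two limits leave unreadable from compound 2 to compound 3 each join two limits and give neither a size nor a direction.

The next compound, compound 4 `C#Cc1cccc(C(=O)NCCNC(=O)[C@H](CC(=O)NC(C)(C)C)NS(=O)(=O)c2ccc(C)cc2)c1`, differs from compound 3 as follows: 3-ethynylphenyl in place of 2-hydroxyphenyl on a carbonyl carbon. Within the data shown here, none of the measured steps bears directly on this change, since no measured pair exchanges the hydroxyl-bearing ring for an ethynyl-bearing one, and the steps that are measured are all unreadable. No direction can therefore be drawn from the data, and no step beyond the scatter is expected in this assay; the expected step is a step that the limit leaves unreadable from compound 3 to compound 4.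

Compound 4 is expected to give about 15000 nM in this assay, within 7000 nM to 40000 nM, most likely again as a limit.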

Compound 4, half-maximal effective concentration: > 11000 nM
Compound 4 was reported as a limit (the forecaster's own chance of this, stated with the estimate: 80%); the middle value lies beyond the limit too.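

In this assay compound 4 gives > 11000 nM, which is again a limit and not a number. Its steps from compound 1, compound 2 and compound 3 therefore cannot be read: the limit of > 11000 nM in this assay, at which 4 of the 4 values shown sit.

The compounds shown leave open whether any change of the group on the carbonyl carbon shifts the result in this assay; none of them gives a number.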